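The source may hold more compounds than are shown below. What is called first, only, known or untested is meant among the compounds shown, and "the series" means these compounds.

Compound 3 is `O=C1CSC(c2cccc(F)c2)N1CCN1CCCCC1`. In an ADME assay on Vero cells (Chlorocebus sabaeus) for cytotoxicity, read by neutral red uptake, tested at 12.3 ug/mL (on this read-out higher numbers stand for a weaker effect at the one concentration tested and lower numbers for a stronger effect), compound 3 gives 100%. Two other compounds share its core and differ from it only in the group on one aromatic carbon. Compound 1 is `O=C1CSC(c2cccc(Cl)c2)N1CCN1CCCCC1`, and in this assay compound 1 gives 100%. Compound 2 is `O=C1CSC(c2cccc(O)c2)N1CCN1CCCCC1`, and in this assay compound 2 gives 100%. Compound 3 therefore stands level with both at the digits shown: there is no change at the digits printed from compound 1 to compound 3 (within the scatter) and no change at the digits printed from compound 2 to compound 3 (within the scatter), and likewise no change at the digits printed from compound 1 to compound 2 (within the scatter).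

Compound 4 is `COc1cccc(C2SCC(=O)N2CCN2CCCCC2)c1`. It differs from compound 3 in one place: methoxy in place of fluoro on an aromatic carbon. The three measured steps bear directly on this change, since each of them also exchanges one group on that same aromatic carbon of the same core, and none of them moved this assay beyond its scatter. With every measured compound sitting at the same reading in this assay, there is no basis for expecting the exchange of fluoro for methoxy to behave differently. Compound 4 is therefore expected to show no change at the digits printed from compound 3 to compound 4 (within the scatter), that is, no step beyond the scatter in either direction. The estimate for compound 4 in this assay is 100%, with an expected range from 90% to 100%.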

Compound 4, a percentage reported as activity, at one concentration (the size of the read-out at that concentration, not a potency): 100%
The estimate for compound 4 equals the measured number at the digits printed; the range from low to high includes it.
By their numbers in this assay, from the lowest: compounds 1, 2, 3 and 4 (each within the scatter of the next).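

In this assay, the exchange of fluoro for methoxy brings two heavy atoms and one hydrogen-bond acceptor to an aromatic carbon that had carried one heavy atom and no acceptor, yet the result is no change at the digits printed from compound 3 to compound 4 (within the scatter) at this position. Methoxy thus extends the series to a group of two heavy atoms, the first here that is larger than a single atom, and the comparison with the chloro compound gives no change at the digits printed from compound 1 to compound 4 (within the scatter) while methyl in place of hydrogen on the oxygen of the hydroxy compound gives no change at the digits printed from compound 2 to compound 4 (within the scatter), so covering that oxygen and removing its hydrogen makes no difference that this read-out can detect among these compounds. Nothing in the material shown accounts for this uniform reading.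

With all four compounds level, the series does not yet show any group on this aromatic carbon that separates from the others in this assay at the one concentration tested. As far as these compounds go, whether an amine, a carboxylic acid or a longer chain such as butoxy on that carbon would give a lower reading remains open, as does the effect of any of these groups on another carbon of the aromatic ring.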